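Imidazopyrimidine series: thiazole to pyrazole at the aryl position

This account rests on a few compounds, and the source may have more. Where it says the series, first, only, none or still open, it means among the compounds named here.

Measured compounds:
- compound 1 `CCc1c(OC)nc2nc(-c3nc(C)cs3)cn2c1C`: > 50 mg/kg
- compound 2 `CCc1c(OC)nc2nc(-c3nc(C(F)(F)F)cs3)cn2c1C`: > 50 mg/kg
- compound 3 `CCCc1c(OC)nc2nc(-c3nc(C)cs3)cn2c1C`: > 50 mg/kg

All three compounds share one core and were tested in a functional assay on the whole organism with Rattus norvegicus as the target; on this read-out lower numbers stand for an effect already at smaller amounts and higher numbers for an effect only at larger amounts of compound. Compound 1 gives only a limit of the assay, > 50 mg/kg, and no number. Compound 2 likewise gives only a limit, > 50 mg/kg. Compound 3 also gives only a limit, > 50 mg/kg. Where compound 1 stands cannot be fixed on a scale; the limit of > 50 mg/kg in this assay, at which 3 of the 3 values shown sit, is all the three values show. The two steps from it are therefore unreadable: a step that the two limits leave unreadable from compound 1 to compound 2 and a step that the two limits leave unreadable from compound 1 to compound 3 cannot be read in size or direction.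

Compound 4 `CCc1c(OC)nc2nc(-c3cc(C)[nH]n3)cn2c1C` is not yet measured. It differs from compound 1 by 5-methyl-1H-pyrazol-3-yl in place of 4-methyl-1,3-thiazol-2-yl on an aromatic carbon; a 5-methyl-1H-pyrazol-3-yl enters where a 4-methyl-1,3-thiazol-2-yl leaves, on an aromatic carbon of a five-membered aromatic ring with 2 nitrogen, part of a fused or bridged system of two rings. For the measured compounds named here, no measured step touches this position; the two measured steps touch other groups and neither is readable. There is thus no ground to expect a step beyond the scatter in either direction in this assay.

Compound 4 is accordingly expected to sit near the same limit, with an estimate of 60 mg/kg, spanning 20 mg/kg to 200 mg/kg. The expected step that the limit leaves unreadable from compound 1 to compound 4 is essentially no change, with a real chance that again only a limit is reported.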

Compound 4, minimum effective dose: > 50 mg/kg
Compound 4: a limit, no number (the forecaster's own chance of this, stated with the estimate: 70%); the middle value is on the limit's open side.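

In this assay compound 4 gives > 50 mg/kg, a limit and not a number. No step among compound 1, compound 2, compound 3 and compound 4 can be read, in size or direction: the limit of > 50 mg/kg in this assay, at which 4 of the 4 values shown sit.

The compounds shown leave open whether any of these groups, 5-methyl-1H-pyrazol-3-yl included, gives a numerical minimum effective dose in this assay.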